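Phenyl for Benzyl on Two Related Cores

The source may report more compounds than this note shows. Statements on the series, on what has been measured and on what is new or still open speak of the compounds shown alone.

Compound 1 `O=C(NCc1cc(Cl)ccc1-n1cnnn1)[C@@H]1CC=NN1C(=O)[C@H](O)c1ccccc1` and compound 2 `O=C(NCc1cc(Cl)ccc1-n1cnnn1)[C@@H]1CC=NN1C(=O)[C@H](O)Cc1ccccc1` share one core, while compound 3 `O=C(NCc1cc(Cl)ccc1-n1cnnn1)[C@@H]1[C@@H]2C[C@@H]2CN1C(=O)[C@H](O)Cc1ccccc1` and compound 4 `O=C(NCc1cc(Cl)ccc1-n1cnnn1)[C@@H]1[C@@H]2C[C@@H]2CN1C(=O)[C@H](O)c1ccccc1` share another; the difference between the two cores is not broken down here. In a functional assay on a cell-free system (plasma, Homo sapiens), with a stated time of 3 min (on this read-out lower numbers stand for stronger inhibition and higher numbers for weaker inhibition), compound 1 gives 840 nM, compound 2 gives 1400 nM, and compound 3 gives 970 nM. The change phenyl in place of benzyl on a saturated chain carbon bound to a carbonyl carbon and an oxygen on a saturated carbon made a step of a 1.7-fold lower number from compound 2 to compound 1 (0.22 log units; within the scatter). Compound 4 carries the same change on its own core, (phenyl in place of benzyl on a saturated chain carbon bound to a carbonyl carbon and an oxygen on a saturated carbon), with the place described in identical words. Because the step of a 1.7-fold lower number from compound 2 to compound 1 (0.22 log units; within the scatter) stayed within the scatter, a step of the same kind is expected for compound 4, a 1.6-fold lower number from compound 3 to compound 4 (0.21 log units; within the scatter), with wide room either way. Compound 4 is therefore estimated at 600 nM, between 250 nM and 1500 nM.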

Compound 4, half-maximal inhibitory concentration: 700 nM
Estimate against measurement, compound 4: 1.2-fold (0.07 log units) below, and the stated range covers the measured number.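

On the core of compound 3, phenyl in place of benzyl gave a 1.4-fold lower number from compound 3 to compound 4 (0.14 log units; within the scatter) in this assay. Set beside the step on the core of compound 1, the change reads alike on both cores: the same change on two cores in this assay, a 1.7-fold lower number (0.22 log units; within the scatter) from compound 2 to compound 1 and a 1.4-fold lower number (0.14 log units; within the scatter) from compound 3 to compound 4, 1.2-fold (0.08 log units) apart, within the scatter of two such steps Both steps lie within the scatter, so the pair shows only that the change carried from one core to the other with no visible difference; it does not show that the change itself moves the number, or that it would behave alike on any further core.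

The compounds shown leave open what a longer chain, such as 2-phenylethyl, would do at this place. They also leave open whether an amine in place of the hydroxyl group would give a step beyond the scatter.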